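Swapping the urea aryl group in a Ret kinase series

The compounds below may be only part of what the source reports. "The series", "measured", "known", "first", "only" and "open" are said of these compounds alone.

Of the compounds shown here, two have been tested in an assay on isolated protein for inhibition of proto-oncogene tyrosine-protein kinase receptor Ret (Homo sapiens), read by mobility shift assay, with a stated time of 1 h, tested at 10 uM; on this read-out lower numbers stand for less inhibition and higher numbers for more inhibition at the one concentration tested (going by the name of the read-out). Compound 1 `CCN(CC)CCn1cnnc1-c1cc(Oc2ccc(NC(=O)Nc3ccc(F)c(F)c3)cc2F)ccn1` gives 7.1% in this assay. Compound 2 `CN(C)CCCn1cnnc1-c1cc(Oc2ccc(NC(=O)Nc3ccc(Cl)c(C(F)(F)F)c3)cc2F)ccn1` gives 79.3%, the higher of the two numbers, and its lead over compound 1 is far beyond the usual scatter of repeat measurements.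

Compound 3 `CN(C)CCCn1cnnc1-c1cc(Oc2ccc(NC(=O)Nc3ccc(F)c(F)c3)cc2F)ccn1` has not yet been measured. It keeps the whole of compound 2 except for one change: 3,4-difluorophenyl in place of 4-chloro-3-(trifluoromethyl)phenyl on an amide-type nitrogen. Going by the values given here, no measured pair shows this exact exchange on its own, so its effect has to be judged indirectly. Compound 1 carries the same 3,4-difluorophenyl group and gives only 7.1% in this assay, although compound 1 also differs in its amine-bearing chain. On that basis a large drop in this assay is expected for compound 3. The expected step in this assay is a number 59.3 percentage points lower from compound 2 to compound 3 (beyond the scatter). Compound 3 is therefore estimated at 20%, within a range from 0% to 55%.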

Compound 3, a percentage reported as inhibition, at one concentration (the size of the read-out at that concentration, not a potency): 30.9%
Compound 3: middle estimate off by 10.9 percentage points, on the low side; the range from low to high includes it.
By their numbers in this assay, from the lowest: compound 1; then compound 3; then compound 2.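

In this assay, the exchange on the amide-type nitrogen can now be read on its own: 3,4-difluorophenyl in place of 4-chloro-3-(trifluoromethyl)phenyl gives a number 48.4 percentage points lower from compound 2 to compound 3 (beyond the scatter), a large step. The amine-bearing chain also counts, as (dimethylamino)methyl in place of diethylamino, with 3,4-difluorophenyl held fixed, gives a number 23.8 percentage points higher from compound 1 to compound 3 (beyond the scatter), a modest step, so the aryl group and the chain both contribute to the readings in this series. No measurement here explains why either change moves the inhibition.

Open, going by these compounds, is how a phenyl group carrying only the chloro or only the trifluoromethyl substituent would read on the same nitrogen, which would separate the two. Also open, on these data alone, is whether the chain effect holds with 4-chloro-3-(trifluoromethyl)phenyl in place, or with a pyrrolidine at the chain end.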